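A few compounds are considered here, and "the series" means these few. Any claim that something is new, unique, unknown or untested is made for them only; others in the source may bear on it.

Of the compounds shown here, two in this set have been measured in an assay on RBL-1 cells for inhibition of Polyunsaturated fatty acid 5-lipoxygenase (Rattus norvegicus); on this read-out higher numbers stand for weaker inhibition and lower numbers for stronger inhibition. Compound 1 `O=C1NC(CO)CN(c2ccccc2)N1` gives 40000 nM in this assay, and compound 2 `Cc1cccc(N2CC(C)NC(=O)N2)n1` gives 3800 nM. Of the two numbers, compound 2 has the lower one, and its gap to compound 1 lies beyond the usual scatter of repeated measurements, so compound 2 is the stronger inhibitor of the pair. Compound 3 `CC1CN(c2cccc(F)n2)NC(=O)N1` has not yet been measured. It differs from compound 2 in one place: fluoro in place of methyl on an aromatic carbon. For the measured compounds named here, no measured pair differs by this same change, so there is no step on which to rest an expectation. An exchange of one single group for another is expected to move the number only a little, within the scatter or just beyond it, toward weaker inhibition. The expected step is a 1.3-fold higher number from compound 2 to compound 3 (0.12 log units; within the scatter). Compound 3 is therefore estimated at 5000 nM in this assay, with a likely range from 2000 nM to 12000 nM.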

Compound 3, half-maximal inhibitory concentration: 6600 nM
The estimate for compound 3 lay 1.3-fold (0.12 log units) below the measured number; the measured number falls inside the stated range.
By their numbers in this assay, from the lowest: compounds 2 and 3 (each within the scatter of the next); then compound 1.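

In this assay, fluoro in place of methyl on this aromatic carbon, next to the ring nitrogen, gives a 1.7-fold higher number from compound 2 to compound 3 (0.24 log units; within the scatter) and so leaves the two compounds indistinguishable on this read-out. For the compounds shown here, the earlier compounds offered no pair differing at this position, so this is the only direct reading of it here: either of these two groups can sit there without a difference that repeated measurement could separate from scatter. No measurement at hand bears on the reason for this result.

On these data alone, whether a plain hydrogen, a chlorine or a larger group such as methoxy or an amine at this same carbon would also leave the number in place remains open. One exchange at one position also says nothing about the rest of the molecule.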